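A few compounds are considered here, and "the series" means these few. Any claim that something is new, unique, unknown or untested is made for them only; others in the source may bear on it.

Two measured compounds share one core. Compound 1 `CC(=O)OCc1ccc2oc(=O)c(C(=O)Oc3cccc(Br)c3)cc2c1` in a functional assay on HT-1080 cells (Homo sapiens), read by transwell migration, with a stated time of 24 h, tested at 1 uM (on this read-out lower numbers stand for a stronger effect and higher numbers for a weaker effect at the one concentration tested), gives 21.8%. Compound 2 `CC(=O)OCc1ccc2oc(=O)c(C(=O)N(C)c3ccccc3Cl)cc2c1` in this assay gives 62.8%, the higher of the two numbers, and the measured step of a number 41 percentage points higher from compound 1 to compound 2 (beyond the scatter) was large. Compound 3 `CC(=O)OCc1ccc2oc(=O)c(C(=O)N(C)c3ccc(Cl)cc3)cc2c1` has not yet been measured. It differs from compound 2 by 4-chlorophenyl in place of 2-chlorophenyl on an amide-type nitrogen. Among the measured compounds shown here, the single measured step exchanged a whole oxygen-linked group for a nitrogen-linked one and so does not speak to a change that only moves the chlorine within the same ring; no step of that kind has been measured here, so there is no basis for expecting a shift beyond the scatter. For compound 3 the expected step is a number 2.8 percentage points lower from compound 2 to compound 3 (within the scatter). Compound 3 is therefore estimated at 60%, with a range from 40% to 80% in this assay.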

Compound 3, a percentage reported as activity, at one concentration (the size of the read-out at that concentration, not a potency): 98.6%
Estimate against measurement, compound 3: 38.6 percentage points below; the measured number lies above the stated range.
By their numbers in this assay, from the lowest: compound 1; then compound 2; then compound 3.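

In this assay, 4-chlorophenyl in place of 2-chlorophenyl on an amide-type nitrogen gives a number 35.8 percentage points higher from compound 2 to compound 3 (beyond the scatter), so where the chlorine sits on this ring matters a great deal, even though the two groups have the same atoms. Replacing 3-bromophenoxy on the carbonyl carbon with (4-chlorophenyl)(methyl)amino gives a number 76.8 percentage points higher from compound 1 to compound 3 (beyond the scatter), which leaves compound 3 with the highest number and the weakest effect of the three. Nothing given here explains why the place of the chlorine counts for so much.

On these data alone, it remains open whether a plain phenyl ring, with no chlorine, would fall nearer compound 2 or compound 3, and whether fluorine or a methoxy group would behave like the chlorine. The gap might also change if a hydrogen replaced the methyl on the nitrogen.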